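The source may hold more compounds than are shown below. What is called first, only, known or untested is meant among the compounds shown, and "the series" means these compounds.

Of the compounds shown here, three sharing a common core have been tested in a toxicity assay on cells (Macrophage, Mus musculus, strain BALB/c) for cytotoxicity, read by MTT assay; on this read-out higher numbers stand for weaker inhibition and lower numbers for stronger inhibition. Compound 1 `COCc1cc(O)c(C(=O)/C=C/c2cc(OC)c(OC)c(OC)c2)c(OC)c1` gives 133000 nM. Compound 2 `C=CCOc1cc(OC)c(C(=O)/C=C/c2cccc(OC)c2)c(OCC=C)c1` gives 13100 nM, the lower of the two numbers available, and its gap to compound 1 lies beyond the usual scatter. Compound 3 `COCc1cc(COC)c(C(=O)/C=C/c2ccc(OC)cc2)c(OC)c1` gives no number, only a limit of the assay, > 250000 nM. Compound 2 therefore stands lowest among the numbers shown, although the three compounds differ in more than one place, so the gaps between them cannot be assigned to any single change.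

The next compound to be measured is compound 4 `C=CCOc1cc(OC)c(C(=O)/C=C/c2ccc([N+](=O)[O-])cc2)c(OCC=C)c1`, which has 4-nitrophenyl in place of the 3-methoxyphenyl of compound 2, on a double-bonded chain carbon bound to a double-bonded chain carbon (4-nitrophenyl in place of 3-methoxyphenyl on a double-bonded chain carbon bound to a double-bonded chain carbon). Within the data shown here, no measured pair isolates this change. The expectation therefore starts from compound 2 at 13100 nM, and no shift beyond the scatter is expected in this assay, in either direction. The estimated step of a 1.1-fold higher number from compound 2 to compound 4 (0.06 log units; within the scatter) is accordingly small. Compound 4 is expected at 15000 nM, with an estimated range of 4000 nM to 60000 nM.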

Compound 4, half-maximal inhibitory concentration: 13200 nM
Beside the measured number, compound 4's estimate is 1.1-fold (0.06 log units) above it; measured number inside the range.
By their numbers in this assay, from the lowest: compounds 2 and 4 (each within the scatter of the next); then compound 1. At a limit, above all of these: compound 3.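

Compounds 1, 2 and 3 differ in more than one place, so they gave no readable step, and the new pair supplies the first one: in this assay the exchange of 3-methoxyphenyl for 4-nitrophenyl gives a 1.0-fold higher number from compound 2 to compound 4 (0.00 log units; within the scatter). On a double-bonded chain carbon bound to a double-bonded chain carbon, then, the assay does not separate these two groups, although the aromatic ring is all they have in common, one bringing a methoxy group and the other a nitro group. This holds for this single pair on this one core, and nothing measured here bears on why the two compounds read alike.

From the compounds shown here alone, whether the same holds for other groups at this place stays open, for instance a 4-aminophenyl, a 4-carboxyphenyl or an unsubstituted phenyl, any of which might or might not read like compound 2 and compound 4. The compounds shown also leave open whether this exchange would read the same on the differently substituted core of compound 1 or compound 3.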